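This account rests on a few compounds, and the source may have more. Where it says the series, first, only, none or still open, it means among the compounds named here.

Compound 1 `Cc1ccc2ccc(-c3cccc(C#N)c3)cc2n1` is the starting point. In a functional assay on CHO cells for inhibition of metabotropic glutamate receptor 5 (Rattus norvegicus), read by FLIPR and calcium flux (on this read-out higher numbers stand for weaker inhibition and lower numbers for stronger inhibition), compound 1 gives 7.7 nM, the lowest number among the compounds that give one. Compound 2 `Cc1ccc2ccc(-c3cccc(CO)c3)cc2n1` gives 8700 nM, and the change hydroxymethyl in place of cyano on an aromatic carbon is a 1100-fold higher number from compound 1 to compound 2 (3.05 log units; beyond the scatter). Compound 3 `Cc1ccc2ccc(-c3cccc(C(N)=O)c3)cc2n1` sits at the limit (the limit of > 10000 nM in this assay, at which 1 of the 3 values shown sits), reported as > 10000 nM. The step of an at least 1200-fold higher number from compound 1 to compound 3 (3.11 log units; beyond the scatter), carbamoyl in place of cyano on an aromatic carbon, is likewise large. Compound 4 `Cc1ccc2ccc(-c3cc(C#N)cc(OC(F)(F)F)c3)cc2n1` keeps the cyano group and differs from compound 1 by trifluoromethoxy in place of hydrogen on an aromatic carbon. Both measured steps replace the cyano group itself; none tests adding a group while the cyano stays. Compound 4 is therefore expected to remain near compound 1, with the step of a 1.3-fold higher number from compound 1 to compound 4 (0.11 log units; within the scatter) small. The estimate for compound 4 is 10 nM, between 2 nM and 60 nM.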

Compound 4, half-maximal inhibitory concentration: 75 nM
Estimate against measurement, compound 4: 7.5-fold (0.88 log units) below, outside the stated range (above it).
By their numbers in this assay, from the lowest: compound 1; then compound 4; then compound 2. At a limit, above all of these: compound 3.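

In this assay, with the cyano group kept, trifluoromethoxy in place of hydrogen on the aromatic carbon meta to that cyano group gives a 9.7-fold higher number from compound 1 to compound 4 (0.99 log units; beyond the scatter) and so weakens inhibition beyond the scatter. This place on the ring therefore does not take the new group without a loss, although the loss is smaller than in a 1100-fold higher number from compound 1 to compound 2 (3.05 log units; beyond the scatter) where the cyano group itself was replaced. Nothing given here accounts for the size of this step.

From the compounds shown here alone, whether a fluorine atom, a methoxy group or an amine at this same place would give a similar step stays open. Going by these compounds, how a carboxylic acid in place of the cyano group would compare also stays open.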